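A few compounds are considered here, and "the series" means these few. Any claim that something is new, unique, unknown or untested is made for them only; others in the source may bear on it.

Compound 1 `O=C(/C=C/c1ccc(Br)cc1)c1cccc(-c2cccc(F)c2)c1`: 18200 nM
Compound 2 `COc1cccc(/C=C/C(=O)c2cccc(-c3cccc(F)c3)c2)c1OC`: 13500 nM
Compound 3 `O=C(/C=C/c1cccc(Br)c1)c1cccc(-c2cccc(F)c2)c1`: 8610 nM

In a functional assay on SW480 cells (Homo sapiens) for cytotoxicity, read by sulforhodamine B assay, with a stated time of 48 h (a higher number here means a weaker inhibitor, a lower number a stronger inhibitor), compound 3 gives 8610 nM. This value lies within the scatter of compound 2, at 13500 nM, so those two cannot be told apart. Only compound 1 is separated from compound 3, by a 2.1-fold lower number from compound 1 to compound 3 (0.33 log units; beyond the scatter).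

Compound 4 `COc1ccccc1/C=C/C(=O)c1cccc(-c2cccc(F)c2)c1` has 2-methoxyphenyl in place of 3-bromophenyl on a double-bonded chain carbon bound to a double-bonded chain carbon. Among the compounds with values here, no measured step makes this exact exchange. Within the data shown here, the one measured step that bears on it is the modest change between the two bromophenyl groups, a 2.1-fold lower number from compound 1 to compound 3 (0.33 log units; beyond the scatter). Compound 2, which also has methoxy groups on this ring, gives 13500 nM, so a methoxy-bearing ring is expected to stay in the same range in this assay. A small change toward a higher number is therefore expected, probably not beyond the scatter. The expected change is a 1.4-fold higher number from compound 3 to compound 4 (0.14 log units; within the scatter). For compound 4, the estimated value is 12000 nM, with an expected range of 6000 nM to 24000 nM.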

Compound 4, half-maximal inhibitory concentration: 16600 nM
For compound 4 the middle estimate is 1.4-fold (0.14 log units) below the measured one; measured number inside the range.
By their numbers in this assay, from the lowest: compounds 3, 2, 4 and 1 (each within the scatter of the next, the first and the last beyond it).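

In this assay, 2-methoxyphenyl at this double-bonded chain carbon cannot be told apart from 3-bromophenyl (a 1.9-fold higher number from compound 3 to compound 4 (0.29 log units; within the scatter)) or from 4-bromophenyl (a 1.1-fold lower number from compound 1 to compound 4 (0.04 log units; within the scatter)), even though the two bromophenyl compounds are separated from each other. Taking away one methoxy from the ring of compound 2 also leaves the reading within the scatter (a 1.2-fold higher number from compound 2 to compound 4 (0.09 log units; within the scatter)). Within the data shown here, compound 4 thus bridges the only separated pair, and neither the one-methoxy nor the two-methoxy ring stands apart from the others. Nothing shown explains these readings. The compounds shown leave open whether an amine or a carboxylic acid on this ring would move the number beyond the scatter, and what changes elsewhere on the shared core would do.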